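Dropping a Chloro Group on a Low-Toxicity Scaffold

The compounds below may be only part of what the source reports. "The series", "measured", "known", "first", "only" and "open" are said of these compounds alone.

Of the compounds shown here, three have been tested in a functional assay on HT-29 cells (Homo sapiens) for cytotoxicity, read by sulforhodamine B assay (on this read-out higher numbers stand for lower toxicity in this test and lower numbers for higher toxicity in this test), and every value so far is a limit of the assay rather than a number.

Compound 1 `O=c1oc2ccc(Cl)cc2cc1-c1cn2nc(-c3c([O-])[o+]nn3-c3ccc(Cl)cc3)sc2n1` gives > 80 ug/mL, a limit.
Compound 2 `O=c1oc2ccc(Cl)cc2cc1-c1cn2nc(-c3c([O-])[o+]nn3-c3ccccc3)sc2n1` gives > 80 ug/mL, a limit.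
Compound 3 `O=c1oc2ccc(Br)cc2cc1-c1cn2nc(-c3c([O-])[o+]nn3-c3ccc(Cl)cc3)sc2n1` gives > 70 ug/mL, a limit.

Two of the three values sit at the limit of > 80 ug/mL in this assay, at which 2 of the 3 values shown sit, and one sits at the limit of > 70 ug/mL in this assay, at which 1 of the 3 values shown sits. Compound 2 differs from compound 1 by hydrogen in place of chloro on an aromatic carbon, and the step that the two limits leave unreadable from compound 1 to compound 2 cannot be read because both ends are limits. The two cores differ by bromo in place of chloro on an aromatic carbon, and the step that the two limits leave unreadable from compound 1 to compound 3 is likewise unreadable.

Compound 4 `O=c1oc2ccc(Br)cc2cc1-c1cn2nc(-c3c([O-])[o+]nn3-c3ccccc3)sc2n1` is not yet measured. It differs from compound 3 by hydrogen in place of chloro on an aromatic carbon, the same change as that from compound 1 to compound 2, made at the same place. Since that earlier change left a limit on both sides, the step that the limit leaves unreadable from compound 3 to compound 4 is expected to be small and probably again unreadable. Compound 4 is therefore estimated at 100 ug/mL in this assay, with a likely range from 60 ug/mL to 200 ug/mL, most probably reported as a limit.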

Compound 4, concentration lethal to 50% of the cells: > 70 ug/mL
Compound 4: no number, only a limit; the forecaster's own chance of this, stated with the estimate: 85%; the middle value lies beyond the limit too.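

In this assay compound 4 gives > 70 ug/mL, which is a limit of the assay. The steps to compound 4 from compound 3 and from compound 2 therefore cannot be read. The compounds shown leave open what the lethal concentration of any of the four actually is, and whether swapping chloro, bromo or hydrogen changes it at all.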